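This account rests on a few compounds, and the source may have more. Where it says the series, first, only, none or still open, it means among the compounds named here.

Measured compounds:
compound 1, `CSCC[C@H](NC(=O)CN(c1nc(Cl)nc2[nH]cnc12)C1CC1)C(=O)OCc1ccccc1`, with 44.6%
compound 2, `NCCCC[C@H](NC(=O)CN(c1nc(Cl)nc2[nH]cnc12)C1CC1)C(=O)OCc1ccccc1`, with 35.3%
compound 3, `CSCC[C@H](NC(=O)CN(c1nc(Cl)nc2[nH]cnc12)C1CC1)C(=O)O`, with 14%

In a functional assay on the whole organism (Tail, strain ICR) with Mus musculus as the target, in the tail flick test, with a stated time of 90 min, at a dose of 25 umol/kg by the oral route (on this read-out lower numbers stand for a weaker effect and higher numbers for a stronger effect at the one dose given), compound 3 stands lowest of the three numbers; its gap to compound 2 is beyond the usual scatter, and its gap to compound 1 is larger still, as the step of a number 30.6 percentage points lower from compound 1 to compound 3 (beyond the scatter) shows. Compound 4, `NCCCC[C@H](NC(=O)CN(c1nc(Cl)nc2[nH]cnc12)C1CC1)C(=O)O`, has not yet been measured. It differs from compound 3 in one place: 2-aminoethyl in place of methylsulfanyl on a saturated chain carbon, three bonds along the chain from an amide-type nitrogen and a carbonyl carbon. The same change has been made once before, from compound 1 to compound 2, where it gave a number 9.3 percentage points lower from compound 1 to compound 2 (within the scatter). Among the compounds with values here, that single step is the only guide, and it lay within the scatter, so no step beyond the scatter is expected from compound 3 to compound 4 either. Compound 3 already starts low, so the room for a further fall is small. Compound 4 is therefore expected to give 9%, with a range from 0% to 24%. That estimate means an expected step of a number 5 percentage points lower from compound 3 to compound 4 (within the scatter).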

Compound 4, a percentage reported as activity, at one dose (the size of the read-out at that dose, not a potency): 28.8%
For compound 4 the middle estimate is 19.8 percentage points below the measured one; the measured number lies above the stated range.
By their numbers in this assay, from the lowest: compound 3; then compounds 4, 2 and 1 (each within the scatter of the next, the first and the last beyond it).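

In this assay, putting 2-aminoethyl in place of methylsulfanyl on the carboxylic acid core gives a number 14.8 percentage points higher from compound 3 to compound 4 (beyond the scatter), so the outcome of this change at this chain position depends on what sits on the oxygen next to the carbonyl group: the same change on two cores in this assay, a number 9.3 percentage points lower (within the scatter) from compound 1 to compound 2 and a number 14.8 percentage points higher (beyond the scatter) from compound 3 to compound 4, 24.1 percentage points apart, beyond the scatter of two such steps Seen from the other side, removing benzyl has a large effect with the methylsulfanyl chain, but with the amine chain it gives a number 6.5 percentage points lower from compound 2 to compound 4 (within the scatter): the same change on two cores in this assay, a number 30.6 percentage points lower (beyond the scatter) from compound 1 to compound 3 and a number 6.5 percentage points lower (within the scatter) from compound 2 to compound 4, 24.1 percentage points apart, beyond the scatter of two such steps The two changes therefore do not simply add up across these four compounds.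

Why they interact cannot be read from these numbers. Going by these compounds, it also remains open whether a methyl ester in place of the benzyl ester, or a guanidine at the end of the chain, would follow the same pattern.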